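From Hydrogen to (Methylsulfanyl)methyl on Compound 3

A few compounds are considered here, and "the series" means these few. Any claim that something is new, unique, unknown or untested is made for them only; others in the source may bear on it.

Within the data shown here, in a functional assay on BGC832 cells (Homo sapiens) for cytotoxicity, read by MTT assay, with a stated time of 24 h (a lower number here means a stronger inhibitor, a higher number a weaker inhibitor), compound 3 (`COc1ccc(/C=C\c2cc(OC)c(OC)c(OC)c2)cc1NC(=O)[C@H](C)NC(=O)OC1CC(C)(C)N([O])C(C)(C)C1`) reads 960 nM and holds the lowest number so far. Compound 2 (`COc1ccc(/C=C\c2cc(OC)c(OC)c(OC)c2)cc1NC(=O)C1CC(C)(C)N([O])C1(C)C`) comes nearest at 4930 nM on the same scale. Compound 1 (`COc1ccc(/C=C\c2cc(OC)c(OC)c(OC)c2)cc1NC(=O)C1=CC(C)(C)N([O])C1(C)C`) gives only a limit of the assay (> 100000 nM) and no number.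

The next compound, compound 4 (`COc1ccc(/C=C\c2cc(OC)c(OC)c(OC)c2)cc1NC(=O)[C@H](CCSC)NC(=O)OC1CC(C)(C)N([O])C(C)(C)C1`), differs from compound 3 at one place ((methylsulfanyl)methyl in place of hydrogen on a saturated chain carbon, two bonds along the chain from an amide-type nitrogen and a carbonyl carbon): (methylsulfanyl)methyl in place of hydrogen on a saturated chain carbon, two bonds along the chain from an amide-type nitrogen and a carbonyl carbon. Cut one bond further out, this reads as methyl to 2-(methylsulfanyl)ethyl.

Only one measured step exists among these compounds (an at least 20-fold lower number from compound 1 to compound 2 (1.30 log units; beyond the scatter)) and it is large, but it exchanges a group on a carbonyl carbon and leaves that chain carbon untouched. It bears on the new change only indirectly: the number can move far within this set, yet the step gives neither size nor direction for this group. The expectation is therefore no step beyond the scatter in this assay for this change. The estimated step is as follows (a 1.3-fold higher number from compound 3 to compound 4 (0.10 log units; within the scatter)). For compound 4 the expected value is 1200 nM with 300 nM and 5000 nM as the estimated ends of its range.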

Compound 4, half-maximal inhibitory concentration: 1680 nM
The estimate for compound 4 lay 1.4-fold (0.15 log units) below the measured number; measured number inside the range.
By their numbers in this assay, from the lowest: compounds 3 and 4 (each within the scatter of the next); then compound 2. At a limit, above all of these: compound 1.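

In this assay the step at this saturated chain carbon is a 1.8-fold higher number from compound 3 to compound 4 (0.24 log units; within the scatter), so the move from methyl to 2-(methylsulfanyl)ethyl leaves the reading within the scatter, and compound 3 and compound 4 cannot be told apart. Among these compounds, this is the first measured information about this carbon: the only earlier step, an at least 20-fold lower number from compound 1 to compound 2 (1.30 log units; beyond the scatter), exchanged a group on a carbonyl carbon, and it showed that the number can move far in this set without showing whether it does so here. Within these compounds, then, this chain carbon carries the larger sulfur-bearing group with no step beyond the scatter, although nothing measured here offers an explanation for that outcome.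

The compounds shown leave open whether the same holds for other groups on this carbon, such as an amine, a carboxylic acid, a phenyl ring or a longer chain. They also leave open whether the sulfur atom plays any part in this reading, a question that a plain hydrocarbon chain on the same carbon would address, and a single pair of compounds cannot settle it.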